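A few compounds are considered here, and "the series" means these few. Any claim that something is new, unique, unknown or untested is made for them only; others in the source may bear on it.

Values in a functional assay on MCF7 cells (Homo sapiens) for inhibition, read by MTT assay; a lower number here means a stronger inhibitor of growth, a higher number a weaker inhibitor of growth

Compound 1 `CC1=C(/C=C/C(C)=C/C=C/C(C)=C\C(=O)Nc2ccc(O)cc2)C(C)(C)CCC1n1ccnc1` gives 1990 nM
Compound 2 `CC1=C(/C=C/C(C)=C/C=C/C(C)=C\C(=O)Nc2cccc(F)c2)C(C)(C)CCC1n1ccnc1` gives 5490 nM
Compound 3 `CC1=C(/C=C/C(C)=C/C=C/C(C)=C\C(=O)Nc2ccc(F)cc2)C(C)(C)CCC1n1ccnc1` gives 400 nM

Compound 3 has the lowest number of the three. The next structure, compound 4 `CC1=C(/C=C/C(C)=C/C=C/C(C)=C\C(=O)NCc2ccc(F)cc2)C(C)(C)CCC1n1ccnc1`, carries 4-fluorobenzyl in place of 4-fluorophenyl on an amide-type nitrogen. Within the data shown here, no measured step makes this change. The nearest evidence is from other changes at the same nitrogen: one large step (a 14-fold lower number from compound 2 to compound 3 (1.14 log units; beyond the scatter)) and two modest ones (a 5.0-fold lower number from compound 1 to compound 3 (0.70 log units; beyond the scatter)) and (a 2.8-fold higher number from compound 1 to compound 2 (0.44 log units; beyond the scatter)). These show that this assay responds to changes there, but they do not fix a direction. With compound 3 lowest at 400 nM, a modest rise is expected (a 2.3-fold higher number from compound 3 to compound 4 (0.35 log units; beyond the scatter)). Compound 4 is estimated at 900 nM (expected range 250 nM to 3000 nM).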

Compound 4, concentration for 50% growth inhibition: 1930 nM
For compound 4 the middle estimate is 2.1-fold (0.33 log units) below the measured one; measured number inside the range.
By their numbers in this assay, from the lowest: compound 3; then compounds 4 and 1 (each within the scatter of the next); then compound 2.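

Going from 4-fluorophenyl to 4-fluorobenzyl on the amide-type nitrogen weakens growth inhibition in this assay with (a 4.8-fold higher number from compound 3 to compound 4 (0.68 log units; beyond the scatter)) as the step, so the gain seen with compound 3 does not carry over to the benzyl amide. The benzyl amide still holds (a 2.8-fold lower number from compound 2 to compound 4 (0.45 log units; beyond the scatter)) against the 3-fluorophenyl amide and sits level with the 4-hydroxyphenyl amide (a 1.0-fold lower number from compound 1 to compound 4 (0.01 log units; within the scatter)). No measurement here accounts for these steps.

Open, on these data alone, is whether a longer chain on this nitrogen, such as 4-fluorophenethyl, moves the number further the same way. Also open, as far as these compounds go, is whether plain benzyl matches compound 4.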